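The source may hold more compounds than are shown below. What is called first, only, known or untested is meant among the compounds shown, and "the series" means these compounds.

Compound 1 `Nc1nc(N)c2c(-c3ccco3)cn([C@@H]3O[C@H](CO)[C@@H](O)[C@H]3O)c2n1`: > 20000 nM (a limit)
Compound 2 `Nc1nc(N)c2c(-c3ccsc3)cn([C@@H]3O[C@H](CO)[C@@H](O)[C@H]3O)c2n1`: > 20000 nM (a limit)

In a functional assay on CEM-DNR-bulk cells (Homo sapiens), read by MTT assay, with a stated time of 72 h (on this read-out higher numbers stand for weaker inhibition and lower numbers for stronger inhibition), compound 1 gives > 20000 nM, a limit and not a number. Compound 2 gives > 20000 nM, also a limit. For the measured compounds named here, the series so far amounts to the limit of > 20000 nM in this assay, at which 2 of the 2 values shown sit, so no measured number places compound 1.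

Compound 3 `Cc1nc(N)c2c(-c3ccco3)cn([C@@H]3O[C@H](CO)[C@@H](O)[C@H]3O)c2n1` is the next to read, with the change methyl in place of amino on an aromatic carbon, between two ring nitrogen atoms. Going by the values given here, the one measured step is a step that the two limits leave unreadable from compound 1 to compound 2. It concerns the furan-2-yl group and not the amino group, so it gives no size for this change.

The expectation therefore rests only on compound 1 and its limit of > 20000 nM. The expected step in this assay is a number no higher from compound 1 to compound 3 (the limit leaves the size open), with no clear direction expected and a further limit the likeliest outcome. For compound 3 the estimated value is 20000 nM, with an expected range of 6000 nM to 40000 nM.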

Compound 3, half-maximal inhibitory concentration: > 20000 nM
Compound 3: a limit, no number; the forecaster's own chance of this, stated with the estimate: 70%; the middle value sits exactly at the limit.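

Compound 3 and compound 1 both end at a limit, so the change from amino to methyl gives no readable step: the limit of > 20000 nM in this assay, at which 3 of the 3 values shown sit.

The compounds shown leave open whether methyl in place of amino, or thiophen-3-yl in place of furan-2-yl, changes inhibition at all.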